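Sulfonyl-piperidine series: aryl substituent and liver stability

The source may report more compounds than this note shows. Statements on the series, on what has been measured and on what is new or still open speak of the compounds shown alone.

Three members of the series share a sulfonamide-linked bis-piperidine core and differ in the substitution of the aromatic ring. Compound 1 `COc1ccc(Br)cc1S(=O)(=O)N1CCC(N2CCC(C)CC2)CC1` carries a methoxy group; in an ADME assay on S9 fraction from liver (Mus musculus, strain ICR/CD-1) for metabolic stability, read by LC-MS, using NADPH, with a stated time of 5 min, tested at 2 uM (on this read-out lower numbers stand for a shorter-lived compound and higher numbers for a longer-lived compound), compound 1 gives 0.15 h. Compound 2 `CC1CCN(C2CCN(S(=O)(=O)c3ccc(Br)cc3OC(F)(F)F)CC2)CC1` carries a trifluoromethoxy group, and in this assay compound 2 gives 0.0833 h. Compound 3 `Cc1cc(S(=O)(=O)N2CCC(N3CCC(C)CC3)CC2)c(Cl)cc1Cl`, with methyl and two chloro groups, gives in this assay 0.108 h. Compound 2 shows the lowest number of the three, but the gaps to compound 3 and to compound 1 both lie within the scatter, so no order among them is established; all three are short-lived in this assay.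

Compound 4 `CCc1cc(Br)ccc1S(=O)(=O)N1CCC(N2CCC(C)CC2)CC1` is not yet measured. It differs from compound 2 by ethyl in place of trifluoromethoxy on an aromatic carbon. For the measured compounds named here, no measured pair in the set isolates this change, so there is no step to lean on. Given that compound 1, compound 2 and compound 3 all sit close together in this assay, the step of a 1.3-fold higher number from compound 2 to compound 4 (0.12 log units; within the scatter) is expected to be no larger than the scatter, with no direction predicted. Compound 4 is thus estimated at 0.11 h in this assay, within a range of 0.05 h to 0.25 h.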

Compound 4, half-life: 0.152 h
Compound 4: the middle estimate sits 1.4-fold (0.14 log units) below what was measured, within the range that was stated.
By their numbers in this assay, from the lowest: compounds 2, 3, 1 and 4 (each within the scatter of the next).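

For the compounds shown here, on the aromatic carbon ortho to a large group, ethyl in place of trifluoromethoxy gives a 1.8-fold higher number from compound 2 to compound 4 (0.26 log units; within the scatter) in this assay as the only single-place step so far. It shows that this exchange, which takes the oxygen and all three fluorines out of this place, leaves the half-life within the scatter, so ethyl and trifluoromethoxy are not told apart here. Nothing measured alongside these compounds accounts for the size of this step.

On these data alone, whether an amine, a carboxylic acid or a longer chain at this place would give a step beyond the scatter remains open. Also open, as far as these compounds go, is whether the same exchange would read alike with a different substitution on the aromatic ring, as this single pair carries a bromo group throughout.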